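The source may hold more compounds than are shown below. What is called first, only, known or untested is meant among the compounds shown, and "the series" means these compounds.

Of the compounds shown here, two sharing one core have been tested in a functional assay on HEK293 cells for agonist activity at Free fatty acid receptor 1 (Homo sapiens), read by HTRF and inositol phosphate accumulation, with a stated time of 60 min; a higher number here means that more compound is needed for the effect, a lower number that less compound is needed. Compound 1 `Fc1ccc(OC(F)(F)F)cc1-c1ccc2c(c1)CC[C@H](CCc1nnn[nH]1)O2` reached only the limit of the assay, giving > 10000 nM, which is a bound rather than a number. Among the measured compounds shown here, compound 2 `O=C(O)CC[C@H]1CCc2cc(-c3cc(OC4CCC4)ccc3F)ccc2O1` gave 3600 nM, the only plain number in this set, so it stands as the single fixed point against which any further result can be placed. Compound 3 `Fc1ccc(OC2CCC2)cc1-c1ccc2c(c1)CC[C@H](CCc1nnn[nH]1)O2` has not yet been measured in this assay. It differs from compound 2 in one place: 1H-tetrazol-5-yl in place of carboxy on a saturated chain carbon, two bonds along the chain from a saturated ring carbon. For the measured compounds named here, no step between two measured compounds is available to set the size of this exchange. The one other result here is that of compound 1, which sits at the limit of > 10000 nM in this assay, at which 1 of the 2 values shown sits. On that basis compound 3 is expected to need more compound for the same effect, with the step estimated at a 2.5-fold higher number from compound 2 to compound 3 (0.40 log units; beyond the scatter). For compound 3 the expected value is 9000 nM, with a range from 3000 nM to 30000 nM, and a real chance that only a limit is reported.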

Compound 3, half-maximal effective concentration: > 10000 nM
Compound 3 was reported as a limit; the forecaster's own chance of this, stated with the estimate: 45%; middle value at least 1.1-fold (0.04 log units) from the limit.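

Putting 1H-tetrazol-5-yl in place of carboxy on a saturated chain carbon, two bonds along the chain from a saturated ring carbon, gives in this assay an at least 2.7-fold higher number from compound 2 to compound 3 (0.44 log units; beyond the scatter). Among the compounds shown here, this is the first readable size for this exchange at this position, and it is only a minimum, so the real step could be larger. The step between the two tetrazole compounds cannot be read, so the swap of trifluoromethyl for cyclobutyl on the oxygen shows no measurable gain, and compound 1 and compound 3 both end at a limit of the assay rather than at a number: the limit of > 10000 nM in this assay, at which 2 of the 3 values shown sit.

On these data alone, how far beyond that limit either tetrazole compound lies remains open, and so does whether the tetrazole ring would give a readable value with any other group on that oxygen. As far as these compounds go, it is also open whether an acyl sulfonamide or a hydroxamic acid in the same place, or a longer chain carrying the tetrazole ring, would give a lower number than the carboxy group of compound 2.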